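A few compounds are considered here, and "the series" means these few. Any claim that something is new, unique, unknown or untested is made for them only; others in the source may bear on it.

Measured compounds and their numbers:

Compound 1 `O=C(COC(=O)C1=C2C(=NC1=O)c1cccc3cccc2c13)OCC(F)(F)C(F)(F)F` gives 23300 nM in a functional assay on BXPC-3 cells (Homo sapiens) for antiproliferative activity, read by sulforhodamine B assay, with a stated time of 72 h; on this read-out higher numbers stand for weaker inhibition and lower numbers for stronger inhibition.
Compound 2 `C=CCSc1ccc2c3c(cccc13)C1=NC(=O)C(C(=O)OCC)=C12` gives 2500 nM in this assay.
Compound 3 `CCCSc1ccc2c3c(cccc13)C1=NC(=O)C(C(=O)OCC(=O)OCC(F)(F)C(F)(F)F)=C12` gives 54100 nM in this assay.

Compound 3 has the highest of the three numbers. Among the measured compounds shown here, its nearest neighbour is compound 1, and the only single-place step among the measured compounds runs between them: a 2.3-fold higher number from compound 1 to compound 3 (0.37 log units; beyond the scatter). For the measured compounds named here, compound 2 lies furthest away with a much lower number, but it differs from compound 3 in two places, so no single step is drawn between them; only their two values are known.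

Compound 4 `C=CCOC(=O)C1=C2C(=NC1=O)c1cccc3c(SCCC)ccc2c13` is the next compound to be measured. Relative to compound 3 the change is vinyl in place of (2,2,3,3,3-pentafluoropropoxy)carbonyl on a saturated chain carbon bound to an oxygen next to a carbonyl group. Going by the values given here, no measured step covers this change on its own. The step from compound 1 to compound 3 concerns a different part of the molecule and says nothing about the ester. What the values do show is that compound 2, which carries a small ester without the pentafluoropropoxycarbonyl group, gives 2500 nM, far below compound 3. Since compound 4 likewise carries a small ester, a drop in this assay is expected, of about a 12-fold lower number from compound 3 to compound 4 (1.08 log units; beyond the scatter). Compound 4 is therefore estimated at 4500 nM, within a range of 1500 nM to 14000 nM.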

Compound 4, half-maximal inhibitory concentration: 12900 nM
For compound 4 the middle estimate is 2.9-fold (0.46 log units) below the measured one; the range from low to high includes it.
By their numbers in this assay, from the lowest: compound 2; then compounds 4 and 1 (each within the scatter of the next); then compound 3.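

In this assay, the ester end of the molecule now has a step of its own: vinyl in place of (2,2,3,3,3-pentafluoropropoxy)carbonyl, on a saturated chain carbon bound to an oxygen next to a carbonyl group, gives a 4.2-fold lower number from compound 3 to compound 4 (0.62 log units; beyond the scatter). With the propylsulfanyl group held constant, inhibition is therefore stronger without the pentafluoropropoxycarbonyl group, which the step from the earlier pair could not show, as that step concerns a different part of the molecule. The step is modest but beyond the scatter, it rests on this one pair alone, and nothing available explains why the number moves.

The compounds shown leave open whether a longer chain, an amine or a carboxylic acid at this place would take the number further in the same direction or reverse it. They also leave open whether the same exchange would give a step of similar size on compound 1, which carries hydrogen where compound 3 and compound 4 carry propylsulfanyl.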